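Replacing a Methoxy Group with an Acrylamide Substituent

The compounds below may be only part of what the source reports. "The series", "measured", "known", "first", "only" and "open" are said of these compounds alone.

Compound 1 `O=C(CSc1nc(Nc2ccccc2)c2ccccc2n1)Nc1ccccc1Br` gives 10300 nM in a functional assay on NCI-H1975 cells (Homo sapiens) for inhibition, read by MTT assay, with a stated time of 72 h; a lower number here means a stronger inhibitor, a higher number a weaker inhibitor.
Compound 2 `COc1cccc(NC(=O)CSc2nc(Nc3ccccc3)c3ccccc3n2)c1` gives 19400 nM in this assay.

Compound 2 has the higher of the two numbers, but the gap to compound 1, a 1.9-fold higher number from compound 1 to compound 2 (0.27 log units; within the scatter), is within the scatter, so the two cannot be ranked. That single step swaps the aryl group on the amide-type nitrogen and barely moves the read-out.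

Compound 3 `C=CC(=O)Nc1cccc(NC(=O)CSc2nc(Nc3ccccc3)c3ccccc3n2)c1` differs from compound 2 at the same aryl ring: (vinylcarbonyl)amino in place of methoxy on an aromatic carbon. Among the measured compounds shown here, the only measured step that touches this part of the molecule is the one from compound 1 to compound 2, and it was small. For the measured compounds named here, there is no measured pair in which a methoxy is exchanged for a (vinylcarbonyl)amino group, so the evidence for this change is thin and the expectation rests on the observation that substituent swaps on this ring have so far been quiet in this assay.

Compound 3 is therefore expected to give a somewhat lower number than compound 2, a step of about a 2.4-fold lower number from compound 2 to compound 3 (0.38 log units; beyond the scatter), with wide uncertainty. The estimate for compound 3 in this assay is 8000 nM, in the range 1500 nM to 30000 nM.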

Compound 3, half-maximal inhibitory concentration: 8120 nM
The estimate for compound 3 lay 1.0-fold (0.01 log units) below the measured number; the range from low to high includes it.
By their numbers in this assay, from the lowest: compounds 3, 1 and 2 (each within the scatter of the next, the first and the last beyond it).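

In this assay the change from methoxy to (vinylcarbonyl)amino, on an aromatic carbon meta to a large group, gives a 2.4-fold lower number from compound 2 to compound 3 (0.38 log units; beyond the scatter) and so is a modest step, the first among these compounds that lies beyond the scatter. The earlier swap of aryl groups on the amide-type nitrogen, a 1.9-fold higher number from compound 1 to compound 2 (0.27 log units; within the scatter), had not separated its two compounds. Compound 3 still cannot be ranked against compound 1, since replacing 2-bromophenyl with 3-((vinylcarbonyl)amino)phenyl gives only a 1.3-fold lower number from compound 1 to compound 3 (0.10 log units; within the scatter) and stays within the scatter, so the new group separates compound 3 from compound 2 alone.

No measurement given here explains why the step from methoxy to (vinylcarbonyl)amino has the size it has.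

The compounds shown leave open whether the vinyl double bond matters at all, which a saturated propanoylamino group or a plain amine at the same carbon would begin to test. They also leave open whether the (vinylcarbonyl)amino group gives a similar step on another carbon of the ring, or whether a longer chain such as a butenoylamino group keeps it.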